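The source may report more compounds than this note shows. Statements on the series, on what has been measured and on what is new or still open speak of the compounds shown alone.

Measured compounds, with their values in a functional assay on DLD-1 cells (Homo sapiens) for antiproliferative activity, read by CellTiter-Glo, with a stated time of 72 h; a lower number here means a stronger inhibitor, a higher number a weaker inhibitor:
- compound 1, `Cc1c(C)c(S(=O)(=O)N2CCC(N3CCC(C)CC3)CC2)c(C)c2c1OC(C)(C)C2`: 1.2 nM
- compound 2, `Cc1cc(C)cc(-c2cccc(S(=O)(=O)N3CCC(N4CCC(C)CC4)CC3)c2)c1`: 41 nM
- compound 3, `CC1CCN(C2CCN(S(=O)(=O)c3cccc4ccccc34)CC2)CC1`: 0.65 nM

Within this set compound 2 stands at the highest number in this assay. Its nearest neighbour is compound 1, whose number lies beyond the scatter below it, and compound 3 lies further still, also beyond the scatter. On the numbers shown, compound 2 is therefore the weakest inhibitor of the three, and compound 1 and compound 3 both reach the low nanomolar region with compact aryl groups on the sulfonyl.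

The next compound to be measured is compound 4, `CC1CCN(C2CCN(S(=O)(=O)c3cccc(N)c3)CC2)CC1`. Against compound 2 it carries the following change: amino in place of 3,5-dimethylphenyl on an aromatic carbon. Going by the values given here, no pair differing in one place has been measured, so the size of this move has no direct precedent; the only guide is that both compounds without the 3,5-dimethylphenyl, compound 1 and compound 3, sit far below compound 2.

Among the compounds with values here, on that basis the step of a 3.4-fold lower number from compound 2 to compound 4 (0.53 log units; beyond the scatter) is expected to go toward a lower number, of a size beyond the scatter, but with wide uncertainty since the amino group has no counterpart among the measured compounds. Compound 4 is estimated at 12 nM, in the range 2 nM to 80 nM.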

Compound 4, half-maximal inhibitory concentration: 3400 nM
Beside the measured number, compound 4's estimate is 280-fold (2.45 log units) below it, and the stated range ends below it.
By their numbers in this assay, from the lowest: compounds 3 and 1 (each within the scatter of the next); then compound 2; then compound 4.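

In this assay, going by these compounds alone, the position on the aromatic ring, meta to a large group, proves strongly sensitive to what it carries: the change of 3,5-dimethylphenyl to amino gives an 83-fold higher number from compound 2 to compound 4 (1.92 log units; beyond the scatter) and is the first single-place step measured. On this pair the 3,5-dimethylphenyl is by far the better of the two groups, so dropping it in favour of amino does not by itself bring the number down. The pair fixes the direction and size of this change, but no measurement at hand gives a reason for it.

The step swaps a ring of 8 heavy atoms for a single nitrogen, so the compounds shown cannot separate the loss of the 3,5-dimethylphenyl from the arrival of the amino group, and a hydrogen at this place would be the reference that divides the step between them. A methyl, a methoxy or an unsubstituted phenyl at the same place would show whether the number follows the size of the group or the presence of nitrogen.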